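The source may report more compounds than this note shows. Statements on the series, on what has been measured and on what is new or still open speak of the compounds shown alone.

Among the compounds with values here, in a functional assay on HT-29 cells (Homo sapiens) for inhibition, read by sulforhodamine B assay, with a stated time of 72 h (on this read-out higher numbers stand for weaker inhibition and lower numbers for stronger inhibition), compound 1 (`COc1cc2c(Nc3ccc(F)c(Cl)c3)ncnc2cc1OCCCn1ccnc1[N+](=O)[O-]`) gives 2060 nM and compound 2 (`COc1cc2c(Nc3ccc(OCc4cccc(F)c4)c(Cl)c3)ncnc2cc1OCCCn1ccnc1[N+](=O)[O-]`) gives 940 nM, the lower of the two numbers so far. Within the data shown here, the only measured step, a 2.2-fold lower number from compound 1 to compound 2 (0.34 log units; beyond the scatter), is modest and comes with (3-fluorobenzyl)oxy in place of fluoro on an aromatic carbon. Compound 3 (`COc1cc2c(Nc3ccc(OCc4cccc(F)c4)c(Cl)c3)ncnc2cc1OCCCCCn1ccnc1[N+](=O)[O-]`) differs from compound 2 in the chain instead: 2-(2-nitro-1H-imidazol-1-yl)ethyl in place of 2-nitro-1H-imidazol-1-yl on a saturated chain carbon, three bonds along the chain from an oxygen on an aromatic ring. The change lies on a saturated chain carbon, three bonds along the chain from an oxygen on an aromatic ring. Among the measured compounds shown here, no measured step alters this chain, so the one available step shows only a modest range of movement and gives no direction here. No shift beyond the scatter is expected in this assay, and the estimated step is a 1.1-fold lower number from compound 2 to compound 3 (0.04 log units; within the scatter). For compound 3 the estimated value is 850 nM, with an expected range of 330 nM to 2200 nM.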

Compound 3, half-maximal inhibitory concentration: 5040 nM
Compound 3: the middle estimate sits 5.9-fold (0.77 log units) below what was measured; the whole stated range lies below it.
By their numbers in this assay, from the lowest: compound 2; then compound 1; then compound 3.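

In this assay the chain turns out to be a place where activity moves: 2-(2-nitro-1H-imidazol-1-yl)ethyl in place of 2-nitro-1H-imidazol-1-yl gives a 5.4-fold higher number from compound 2 to compound 3 (0.73 log units; beyond the scatter), so here the longer chain carries the weaker number. The earlier pair changed only the aromatic substituent and said nothing about this chain, whereas this one pair shows that its length is not a free variable while the (3-fluorobenzyl)oxy group stays fixed. Nothing available bears on why the number rises with the longer chain.

On these data alone, a single pair gives no trend with length, so a shorter chain and one of intermediate length remain open. Also open, as far as these compounds go, is whether an amine in place of the 2-nitro-1H-imidazol-1-yl end group would respond to the chain in the same way.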